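The source may hold more compounds than are shown below. What is called first, only, known or untested is meant among the compounds shown, and "the series" means these compounds.

Three compounds share a core that carries an ethyl ester and a methoxy group, and each has been tested in an ADME assay on HEK293 cells (Homo sapiens) for cytotoxicity, read by luminescence, with a stated time of 72 h; a higher number here means that more compound is needed for the effect, a lower number that less compound is needed. Compound 1 `CCOC(=O)c1c(-c2cccc(-c3ccccc3)c2)[nH]c2cc(OC)c(Cl)cc2c1=O` reaches only the limit of this assay, > 22000 nM, which is a limit and not a number. Compound 2 `CCOC(=O)c1c(-c2cccc(-c3ccccc3)c2)[nH]c2cc(OC)c(F)cc2c1=O` likewise gives only the limit > 22000 nM. Compound 3 `CCOC(=O)c1c(-c2cccc(F)c2)[nH]c2cc(OC)c(F)cc2c1=O` also gives only the limit > 22000 nM. Compound 2 differs from compound 1 by chloro in place of fluoro on an aromatic carbon, and the step that the two limits leave unreadable from compound 2 to compound 1 cannot be read because of the limit of > 22000 nM in this assay, at which 3 of the 3 values shown sit. Compound 2 differs from compound 3 by fluoro in place of phenyl on an aromatic carbon; the step that the two limits leave unreadable from compound 2 to compound 3 is equally unreadable. Compound 4 `CCOC(=O)c1c(-c2cccc(Cl)c2)[nH]c2cc(OC)c(F)cc2c1=O` remains to be measured; it differs from compound 3 by chloro in place of fluoro on an aromatic carbon. This is the same kind of change as that from compound 2 to compound 1, but there the place was part of a fused or bridged system of two rings, ortho to a methoxy group, meta to a fused ring and para to a fused ring, whereas here it is meta to a large group. Compound 4 is expected to show a step that the limit leaves unreadable from compound 3 to compound 4 in this assay. That expectation rests on compound 3 sitting at its limit > 22000 nM and on (the limit of > 22000 nM in this assay, at which 3 of the 3 values shown sit). Compound 4 is estimated at 30000 nM, between 15000 nM and 100000 nM.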

Compound 4, half-maximal effective concentration: > 22000 nM
Compound 4 was reported as a limit (the forecaster's own chance of this, stated with the estimate: 85%); the middle value lies beyond the limit too.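

Compound 4 gives > 22000 nM in this assay as a limit and not a number. The steps from compound 2 and from compound 3 to compound 4 therefore cannot be read, because the values all stop at the same limit: the limit of > 22000 nM in this assay, at which 4 of the 4 values shown sit.

The compounds shown leave open how much of each is needed for the effect in this assay and whether swapping chloro, fluoro or phenyl changes that amount at all.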